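Calpain-1 series: phenyl in place of the hydroxylated ring

This account rests on a few compounds, and the source may have more. Where it says the series, first, only, none or still open, it means among the compounds named here.

Compound 2 `CCC(NC(=O)C(CC(C)C)NC(=O)OCc1ccccc1)C(=O)C(=O)NCC1(C)CC(O)CC(C)(C)C1` gives 420 nM in an assay on isolated protein for inhibition of Calpain-1 catalytic subunit (Homo sapiens); on this read-out higher numbers stand for weaker inhibition and lower numbers for stronger inhibition. Compound 1 `CCC(NC(=O)C(CC(C)C)NC(=O)OCc1ccccc1)C(=O)C(=O)NCCCCCO` gives 500 nM, and the step of a 1.2-fold lower number from compound 1 to compound 2 (0.08 log units; within the scatter) lies within the scatter, so the two stand together on the numbers shown. Compound 3 `CCC(NC(=O)C(CC(C)C)NC(=O)OCc1ccccc1)C(=O)C(=O)NCc1ccccc1` carries a group of 6 heavy atoms (6 carbon; one six-membered aromatic ring of carbon only) in place of a group of 10 heavy atoms (9 carbon, 1 oxygen; one six-membered non-aromatic ring of carbon only), on a saturated chain carbon bound to an amide-type nitrogen. For the measured compounds named here, the only measured step at this position, a 1.2-fold lower number from compound 1 to compound 2 (0.08 log units; within the scatter), stayed within the scatter and concerns the group that now leaves. On that basis no step beyond the scatter is expected in this assay for compound 3. The expected step is a 1.1-fold higher number from compound 2 to compound 3 (0.03 log units; within the scatter). Compound 3 is estimated at 450 nM, with a range of 200 nM to 1000 nM.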

Compound 3, inhibition constant: 200 nM
The estimate for compound 3 lay 2.3-fold (0.35 log units) above the measured number; measured number inside the range.
By their numbers in this assay, from the lowest: compound 3; then compounds 2 and 1 (each within the scatter of the next).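

In this assay, a 2.1-fold lower number from compound 2 to compound 3 (0.32 log units; beyond the scatter) and a 2.5-fold lower number from compound 1 to compound 3 (0.40 log units; beyond the scatter) are both modest but beyond the scatter, so this place on a saturated chain carbon bound to an amide-type nitrogen does respond to the group it carries. Phenyl stands apart from both 4-hydroxybutyl and the hydroxylated non-aromatic ring, which the earlier step could not separate. Nothing available here bears on the reason for this.

The compounds shown leave open whether the lower number goes with the aromatic ring or with the absence of the hydroxyl. A cyclohexyl or a 4-hydroxyphenyl group in this place would separate the two.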